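Swapping the ring substituent on an oxazole ketone

This account rests on a few compounds, and the source may have more. Where it says the series, first, only, none or still open, it means among the compounds named here.

Measured so far in an assay on HEK-293T cells for inhibition of diacylglycerol lipase-alpha (Homo sapiens), read by colorimetric assay; on this read-out lower numbers stand for stronger inhibition and higher numbers for weaker inhibition:
- compound 1, `O=C(CCCCCCc1ccccc1)c1ncc(-c2cccs2)s1`: > 10000 nM
- compound 2, `O=C(CCCCCCc1ccccc1)c1nc(C(F)(F)F)co1`: 214 nM
- compound 3, `O=Cc1coc(C(=O)CCCCCCc2ccccc2)n1`: 1510 nM

The value for compound 1 is a limit of the assay, not a number; it sits at the limit of > 10000 nM in this assay, at which 1 of the 3 values shown sits. Among the two numbers that were obtained, compound 3 has the highest, that is the weakest inhibition; its nearest neighbour is compound 2, reached by a 7.1-fold higher number from compound 2 to compound 3 (0.85 log units; beyond the scatter), where a formyl group stands in place of a trifluoromethyl group on an aromatic carbon.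

Compound 4, `COc1cnc(C(=O)CCCCCCc2ccccc2)o1`, has not yet been measured in this assay. It differs from compound 3 in a group of 7 heavy atoms (4 carbon, 1 nitrogen, 2 oxygen; one five-membered aromatic ring with 2 hetero atoms) in place of a group of 7 heavy atoms (4 carbon, 1 nitrogen, 2 oxygen; one five-membered aromatic ring with 2 hetero atoms), on a carbonyl carbon: the 4-formyl-1,3-oxazol-2-yl group leaves and a group with no common name enters, on a carbonyl carbon whose other neighbour is a saturated chain carbon. Among the compounds with values here, no measured step shows this particular exchange; the only measured step that touches this ring, from compound 2 to compound 3, was modest but beyond the scatter, so a change of similar size in either direction seems possible. Compound 4 is therefore estimated at 1800 nM, with a range from 500 nM to 7000 nM, which means the step of a 1.2-fold higher number from compound 3 to compound 4 (0.08 log units; within the scatter) is expected to stay close to the scatter.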

Compound 4, half-maximal inhibitory concentration: > 10000 nM
Compound 4: only a limit was reported; the forecaster's own chance of this, stated with the estimate: 15%; middle value at least 5.5-fold (0.74 log units) from the limit.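

In this assay the exchange on the carbonyl carbon brings an at least 6.6-fold higher number from compound 3 to compound 4 (0.82 log units; beyond the scatter) even though both groups have the same heavy atoms, the same kind of ring and the same count of hydrogen-bond acceptors. Matching counts alone are therefore not enough to preserve inhibition at this position, a point that the step from trifluoromethyl to formyl could not show, as those two groups differ in their atoms. Going by these compounds, compound 4 gives only a limit rather than a number, so the full size of this step stays unknown, and the same limit now appears for a second compound: the limit of > 10000 nM in this assay, at which 2 of the 4 values shown sit.

The compounds shown leave open which feature of the entering group matters, as the two groups differ in more than one respect. They also leave open how a nitrile, an amine or a carboxylic acid would fare in place of the formyl group on the ring.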